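The source may hold more compounds than are shown below. What is called first, only, known or untested is meant among the compounds shown, and "the series" means these compounds.

Measured so far:
- Compound 1, `NC(=O)Cn1c(-c2ccc(C(F)(F)F)cc2)nc2cccnc21`: 11.7 mg/kg
- Compound 2, `CN(C)C(=O)Cn1c(-c2ccc(C(F)(F)F)cc2)nc2cccnc21`: 3.2 mg/kg
- Compound 3, `NC(=O)Cn1c(-c2ccc(Cl)cc2)nc2ccc[n+]([O-])c21`: 52.1 mg/kg

All three were tested in a functional assay on the whole organism with Mus musculus as the target; on this read-out lower numbers stand for an effect already at smaller amounts and higher numbers for an effect only at larger amounts of compound. Compound 2 differs from compound 1 by dimethylamino in place of amino on a carbonyl carbon, and this gave a 3.7-fold lower number from compound 1 to compound 2 (0.56 log units; beyond the scatter). Compound 3 carries a different core from compound 1; the difference between the two cores is not broken down here. Compound 4, `CN(C)C(=O)Cn1c(-c2ccc(Cl)cc2)nc2ccc[n+]([O-])c21`, has not yet been measured. Among the compounds with values here, it differs from compound 3 by dimethylamino in place of amino on a carbonyl carbon, the same change as the one between compound 1 and compound 2, at the same kind of place. The step from compound 3 to compound 4 is therefore expected to be similar in size to the earlier one, resting on a 3.7-fold lower number from compound 1 to compound 2 (0.56 log units; beyond the scatter), which gives the expected step of a 3.5-fold lower number from compound 3 to compound 4 (0.54 log units; beyond the scatter). For compound 4 the expected value in this assay is 15 mg/kg, with a likely range from 6 mg/kg to 40 mg/kg.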

Compound 4, dose for half-maximal effect: 20 mg/kg
The estimate for compound 4 lay 1.3-fold (0.12 log units) below the measured number; measured number inside the range.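

In this assay the same change, dimethylamino in place of amino on a carbonyl carbon, gave a 2.6-fold lower number from compound 3 to compound 4 (0.42 log units; beyond the scatter) and so carried over to the second core. Within the data shown here, this rests on only two pairs of compounds, so it says nothing about any further core and gives no reason for the drop in the number. Within those limits, the two steps match in size: the same change on two cores in this assay, a 3.7-fold lower number (0.56 log units; beyond the scatter) from compound 1 to compound 2 and a 2.6-fold lower number (0.42 log units; beyond the scatter) from compound 3 to compound 4, 1.4-fold (0.15 log units) apart, within the scatter of two such steps

Still open, going by these compounds, is how other groups on that carbonyl carbon would behave, such as diethylamino, a pyrrolidine ring, or a hydroxyl that would make a carboxylic acid. Also open, on these data alone, is whether a longer chain in place of carbamoylmethyl would show the same step.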